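This account rests on a few compounds, and the source may have more. Where it says the series, first, only, none or still open, it means among the compounds named here.

Compound 1, `O=C(N/N=C/c1cccc(Br)c1)Nc1ccc(Oc2ccnc3[nH]ccc23)c(F)c1`, is the anchor of this small set. In a functional assay on A549 cells (Homo sapiens) for antiproliferative activity, read by MTT assay, with a stated time of 72 h (a lower number here means a stronger inhibitor, a higher number a weaker inhibitor), compound 1 gives 2220 nM, which is the lowest of the two numbers that were obtained; the nearest is compound 2, whose step lies within the scatter, so compound 1 cannot be called the more potent of the pair. Compound 2, `O=C(N/N=C/c1cccc([N+](=O)[O-])c1)Nc1ccc(Oc2ccnc3[nH]ccc23)c(F)c1`, gives 3640 nM in this assay, and the step of a 1.6-fold higher number from compound 1 to compound 2 (0.21 log units; within the scatter) carries a nitro in place of bromo on an aromatic carbon. Compound 3, `O=C(N/N=C/c1cccc(Cl)c1Cl)Nc1ccc(Oc2ccnc3[nH]ccc23)c(F)c1`, is reported in this assay as "not active" (no number reported), with no number attached to it.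

Compound 4, `O=C(N/N=C/c1ccc(O)cc1O)Nc1ccc(Oc2ccnc3[nH]ccc23)c(F)c1`, has not yet been measured. It differs from compound 1 by 2,4-dihydroxyphenyl in place of 3-bromophenyl on a carbon with a double bond to nitrogen. Going by the values given here, the only measured step that touches the same ring is the one from compound 1 to compound 2, which was within the scatter; compound 3 shows that a second halogen on that ring can remove measurable activity, but no measured step exchanges a halogen for hydroxyls, so the data give no direct guide to the size or direction of this change. Compound 4 is therefore expected to land near compound 1, with a wide range: the estimate for compound 4 is 3000 nM, between 800 nM and 12000 nM, which as a step means a 1.4-fold higher number from compound 1 to compound 4 (0.13 log units; within the scatter).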

Compound 4, half-maximal inhibitory concentration: 5840 nM
The estimate for compound 4 lay 1.9-fold (0.29 log units) below the measured number; the range from low to high includes it.
By their numbers in this assay, from the lowest: compounds 1, 2 and 4 (each within the scatter of the next, the first and the last beyond it).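

In this assay, going by these compounds alone, putting 2,4-dihydroxyphenyl in place of 3-bromophenyl on a carbon with a double bond to nitrogen gives a 2.6-fold higher number from compound 1 to compound 4 (0.42 log units; beyond the scatter), the first step at this position that lies beyond the scatter, although it is a modest one. Against the nitro-bearing ring the same exchange gives a 1.6-fold higher number from compound 2 to compound 4 (0.21 log units; within the scatter), which stays within the scatter, so this position tolerates a ring carrying hydrogen-bond donors and acceptors, where 3-bromophenyl has none, and still returns a number, whereas compound 3 is reported as not active. No evidence is at hand that would account for the step from the bromo compound to the dihydroxy compound.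

The compounds shown leave open whether the step belongs to the two hydroxyls together or to only one of them, since no ring with a single hydroxyl appears among them. They also leave open how a methoxy group, an amine or a carboxylic acid on this ring would compare with the hydroxyls of compound 4 in this assay.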